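The source may report more compounds than this note shows. Statements on the series, on what has been measured and on what is new or still open speak of the compounds shown alone.

Three compounds share one core, and their lipophilicity has been measured in a physicochemical assay for lipophilicity, using the shake flask method, in phosphate buffer, measured as octanol-water partition, with a stated time of 30 min, at pH 7.4; on this read-out lower numbers stand for lower lipophilicity and higher numbers for higher lipophilicity. Compound 1 `CN(C)C(=O)c1cc(-c2cnc(NCc3c(F)ccc4c3CCO4)c3cn[nH]c(=O)c23)n(C)n1` gives 2.1. Compound 2 `O=C1CCCN1c1cnc(NCc2c(F)ccc3c2CCO3)n2cnnc12` gives 1.3, and compound 3 `CN(c1ccccc1)c1cnc(NCc2c(F)ccc3c2CCO3)n2cnnc12` gives 3.6. Compound 1 thus sits second highest of the three, closer to compound 2 than to compound 3. Within the data shown here, the one measured step, a number 2.30 log units higher from compound 2 to compound 3 (beyond the scatter), is a much bigger exchange than the one followed here. Compound 4 `Cn1nccc1-c1cnc(NCc2c(F)ccc3c2CCO3)c2cn[nH]c(=O)c12` differs from compound 1 by hydrogen in place of dimethylcarbamoyl on an aromatic carbon. Removing a group of five heavy atoms with a carbonyl and leaving a bare hydrogen should move the number upward in this assay, but by less than that measured step. The step from compound 1 to compound 4 is expected to be a number 0.70 log units higher from compound 1 to compound 4 (beyond the scatter). Compound 4 is estimated at 2.8, within 2.3 to 3.4.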

Compound 4, distribution coefficient: 2.6
The estimate for compound 4 lay 0.20 log units above the measured number; low and high end bracket the measured number.
By their numbers in this assay, from the lowest: compound 2; then compound 1; then compound 4; then compound 3.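

Exchanging dimethylcarbamoyl for hydrogen on this carbon of the five-membered ring gives a number 0.50 log units higher from compound 1 to compound 4 (beyond the scatter) in this assay. Among these compounds, this is the first reading at this place, and it shows that the number responds to the exchange, although the step is modest. Nothing measured here explains the direction or size of this step. The compounds shown leave open how a carboxylic acid, an amine or a smaller methylcarbamoyl group on this same carbon would compare with hydrogen and dimethylcarbamoyl.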